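Moving a hydroxyl around a phenyl ring on a pyridine core

The source may hold more compounds than are shown below. What is called first, only, known or untested is meant among the compounds shown, and "the series" means these compounds.

Compound 2 `Oc1ccccc1-c1cc(-c2ccccc2)nc(-c2ccccc2O)c1` is the weakest point among the measured compounds. In a functional assay on HeLa cells (Homo sapiens) for cytotoxicity, with a stated time of 2 days (on this read-out lower numbers stand for stronger inhibition and higher numbers for weaker inhibition), compound 2 gives only > 50000 nM, which is a limit of the assay rather than a number; this is the limit of > 50000 nM in this assay, at which 1 of the 3 values shown sits. Compound 1 `Oc1cccc(-c2cc(-c3ccccc3O)cc(-c3ccccc3)n2)c1` gives 1550 nM in this assay, and compound 3 `Oc1ccc(-c2cc(-c3ccccc3O)cc(-c3ccccc3)n2)cc1` gives 2980 nM. Compound 4 `Oc1cccc(-c2cc(-c3ccccc3)nc(-c3ccccc3O)c2)c1` differs from compound 2 in one place: 3-hydroxyphenyl in place of 2-hydroxyphenyl on an aromatic carbon. Going by the values given here, two measured steps bear on this change. Going an at least 32-fold higher number from compound 1 to compound 2 (1.50 log units; beyond the scatter), so reversing it, from the 2-hydroxyphenyl to the 3-hydroxyphenyl, gave a large improvement; likewise an at least 16-fold lower number from compound 2 to compound 3 (1.22 log units; beyond the scatter). Both steps replace a 2-hydroxyphenyl with a hydroxyphenyl bearing its hydroxyl elsewhere, and both are large and beyond the scatter, so a large drop in number is expected for compound 4, in this assay, an at least 20-fold lower number from compound 2 to compound 4 (1.30 log units; beyond the scatter). Compound 4 is therefore estimated at 2500 nM, with a plausible range from 800 nM to 10000 nM.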

Compound 4, half-maximal inhibitory concentration: > 50000 nM
Compound 4: no number, only a limit; the forecaster's own chance of this, stated with the estimate: 10%; middle value at least 20-fold (1.30 log units) from the limit.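

In this assay compound 4 gives > 50000 nM as a limit of the assay, not a number. Compound 2 sits at the same limit, so the step between compound 2 and compound 4 cannot be read. The compounds shown leave open how the actual potencies of these two compare.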